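The compounds below may be only part of what the source reports. "The series", "measured", "known", "first", "only" and "open" are said of these compounds alone.

The three measured compounds share one core and differ only in what sits on the saturated chain carbon bound to a sulfur. Compound 1 `CSc1nc(NCc2ccc(-c3ccccn3)cc2)c2[nH]nc(C(C)C)c2n1` carries hydrogen there, and in a functional assay on HT cells (Homo sapiens) for antiproliferative activity, read by fluorescence, with a stated time of 72 h (on this read-out higher numbers stand for weaker inhibition of growth and lower numbers for stronger inhibition of growth), compound 1 gives 783 nM. Compound 2 `CC(C)c1n[nH]c2c(NCc3ccc(-c4ccccn4)cc3)nc(SCC3CNC(=O)O3)nc12` carries 2-oxo-1,3-oxazolidin-5-yl, and compound 2 gives 80 nM. Compound 3 `CC(C)c1n[nH]c2c(NCc3ccc(-c4ccccn4)cc3)nc(SCCn3ccnc3)nc12` carries (1H-imidazol-1-yl)methyl, and compound 3 gives 155 nM. Among these three numbers compound 3 stands second highest: one of the two steps that reach it, a 1.9-fold higher number from compound 2 to compound 3 (0.29 log units; within the scatter), lies within the scatter, while the other, a 5.1-fold lower number from compound 1 to compound 3 (0.70 log units; beyond the scatter), lies beyond it.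

Compound 4 `CC(C)c1n[nH]c2c(NCc3ccc(-c4ccccn4)cc3)nc(SCCO)nc12` has not yet been measured. It differs from compound 3 in one place: hydroxy in place of 1H-imidazol-1-yl on a saturated chain carbon, two bonds along the chain from a sulfur. Within the data shown here, two measured steps bear on this change. Introducing (1H-imidazol-1-yl)methyl in place of hydrogen gave a 5.1-fold lower number from compound 1 to compound 3 (0.70 log units; beyond the scatter), and introducing 2-oxo-1,3-oxazolidin-5-yl gave a 9.8-fold lower number from compound 1 to compound 2 (0.99 log units; beyond the scatter). Compound 4 keeps a (2-hydroxyethyl)sulfanyl chain but loses the five-membered aromatic ring, so in what it carries it sits between compound 1 and compound 3. The expected step is a 2.3-fold higher number from compound 3 to compound 4 (0.35 log units; beyond the scatter), a somewhat higher number. Compound 4 is therefore estimated at 350 nM, with a range from 150 nM to 900 nM.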

Compound 4, concentration for 50% growth inhibition: 48 nM
Beside the measured number, compound 4's estimate is 7.3-fold (0.86 log units) above it; measured number outside the range, below it.
By their numbers in this assay, from the lowest: compounds 4, 2 and 3 (each within the scatter of the next, the first and the last beyond it); then compound 1.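

In this assay, the swap of 1H-imidazol-1-yl for hydroxy gives a 3.2-fold lower number from compound 3 to compound 4 (0.51 log units; beyond the scatter) and so costs nothing; among these compounds, a five-membered aromatic ring at the end of the chain is not needed for a low number. Hydroxymethyl on the saturated chain carbon bound to a sulfur gives a 16-fold lower number from compound 1 to compound 4 (1.21 log units; beyond the scatter) and, in place of the larger 2-oxo-1,3-oxazolidin-5-yl ring, it gives a 1.7-fold lower number from compound 2 to compound 4 (0.22 log units; within the scatter), so on this read-out the small open chain and that ring cannot be told apart. The 2-hydroxyethyl chain thus keeps the full gain over hydrogen with a single heavy atom entering where the imidazole ring left, although no measurement at hand explains why these steps fall as they do.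

From the compounds shown here alone, whether the hydroxy itself matters remains open, since a methoxy group, an amine or a carboxylic acid at the same chain end could perform just as well. Going by these compounds, it is equally open whether a longer chain, such as 3-hydroxypropyl, would hold these numbers, and all of these comparisons rest on one cell type.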